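The source may hold more compounds than are shown below. What is called first, only, known or untested is meant among the compounds shown, and "the series" means these compounds.

In a functional assay on Venous blood for antagonist activity at C-X-C chemokine receptor type 3 (Homo sapiens), read by flow cytometry, with a stated time of 30 min, in the presence of a further agent that is not named here (a lower number here means a stronger inhibitor, a higher number a weaker inhibitor), compound 2, `Cc1nc(C)n(CC(=O)N2CCN(c3sc(C(F)(F)F)nc3-c3nc4c(F)cccc4[nH]3)C[C@H]2C)n1`, gives 321 nM, which is the lowest of the three numbers recorded so far. Compound 3, `Cc1nc(C)n(CC(=O)N2CCN(c3sc(C(F)(F)F)nc3-c3nc4c(C(F)(F)F)cccc4[nH]3)C[C@H]2C)n1`, gives 747 nM, and compound 1, `COC1CCN(CC(=O)N2CCN(c3sc(C(F)(F)F)nc3-c3nc4ccccc4[nH]3)C[C@H]2C)C1`, gives 3380 nM. Within the data shown here, the one step that joins two measured compounds differing in a single place is a 2.3-fold higher number from compound 2 to compound 3 (0.37 log units; beyond the scatter).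

Compound 4, `Cc1nc(C)n(CC(=O)N2CCN(c3sc(C(F)(F)F)nc3-c3nc4cccc(C)c4[nH]3)C[C@H]2C)n1`, has not yet been measured. It differs from compound 2 by 7-methyl-1H-benzimidazol-2-yl in place of 4-fluoro-1H-benzimidazol-2-yl on an aromatic carbon. Among the measured compounds shown here, no measured pair shows this exact exchange. The step from compound 2 to compound 3 bears on it, since there too the fluoro at the same position of the shared core gave way to a different group, and that change produced a modest rise beyond the scatter. A methyl in place of fluoro is expected to move the number in the same direction, though by less; the estimated step is a 1.6-fold higher number from compound 2 to compound 4 (0.19 log units; within the scatter). Compound 4 is therefore expected to give about 500 nM in this assay, with a likely range from 220 nM to 1150 nM.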

Compound 4, half-maximal inhibitory concentration: 376 nM
The estimate for compound 4 lay 1.3-fold (0.12 log units) above the measured number; the range from low to high includes it.
By their numbers in this assay, from the lowest: compounds 2, 4 and 3 (each within the scatter of the next, the first and the last beyond it); then compound 1.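

The exchange of 4-fluoro-1H-benzimidazol-2-yl for 7-methyl-1H-benzimidazol-2-yl gives a 1.2-fold higher number from compound 2 to compound 4 (0.07 log units; within the scatter) in this assay, so this change leaves the number within the scatter. Among these compounds, until now, the only reading of a change on this benzimidazole was a 2.3-fold higher number from compound 2 to compound 3 (0.37 log units; beyond the scatter), which lies beyond the scatter, and it could not be told whether any replacement of the fluoro would raise the number. The new step shows that at least one replacement, methyl, does not do so, and that the rise seen with trifluoromethyl is not common to every group tried here. Nothing available gives a reason for this result.

As far as these compounds go, it remains open whether chloro, methoxy, nitrile or an amine would stay level with compound 2 or raise the number as trifluoromethyl did. Among the compounds shown here, the effect of the fluoro or methyl itself also remains open, since compound 1, the only compound here without such a group, differs from compound 2 in more than one place.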